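From Acetylfuran to Thiophene in an Aortic Antagonist Series

The source may hold more compounds than are shown below. What is called first, only, known or untested is meant among the compounds shown, and "the series" means these compounds.

Compound 2 `COc1cc2nc(N3CCN(C(=O)c4ccc(C(C)=O)o4)[C@H]4CCCC[C@H]43)nc(N)c2cc1OC` carries a (5-acetylfuran-2-yl)carbonyl group on the amide-type nitrogen in a ring of the shared core. Among the measured compounds shown here, in a functional assay on thoracic aorta for antagonist activity at Alpha-1D adrenergic receptor (Rattus norvegicus) (a lower number here means tighter binding, a higher number weaker binding), compound 2 gives 214 nM, the higher of the two numbers measured so far. Its nearest neighbour is compound 1 `COc1cc2nc(N3CCN(C(=O)c4ccc(Br)o4)[C@H]4CCCC[C@H]43)nc(N)c2cc1OC`, which in this assay gives 58.9 nM. For the measured compounds named here, the single measured step, a 3.6-fold higher number from compound 1 to compound 2 (0.56 log units; beyond the scatter), shows that acetyl in place of bromo raised the number. Compound 3 `COc1cc2nc(N3CCN(C(=O)c4cccs4)[C@H]4CCCC[C@H]43)nc(N)c2cc1OC` has not yet been measured. The change from compound 2 to compound 3 is thiophen-2-yl in place of 5-acetylfuran-2-yl on a carbonyl carbon. Going by the values given here, the step from compound 1 to compound 2 bears on this change, as it removed the same acetyl group, whereas the exchange of furan for thiophene has no measured counterpart here. A modest decrease in this assay is therefore expected, a 3.1-fold lower number from compound 2 to compound 3 (0.49 log units; beyond the scatter). Compound 3 is estimated at 70 nM, within a range from 25 nM to 200 nM.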

Compound 3, dissociation constant: 35.5 nM
For compound 3 the middle estimate is 2.0-fold (0.29 log units) above the measured one, within the range that was stated.
By their numbers in this assay, from the lowest: compounds 3 and 1 (each within the scatter of the next); then compound 2.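

In this assay the exchange of 5-acetylfuran-2-yl for thiophen-2-yl on a carbonyl carbon gives the largest step seen so far (a 6.0-fold lower number from compound 2 to compound 3 (0.78 log units; beyond the scatter)), which shows that this position accepts a different five-membered aromatic ring with no loss of the lower numbers. Thiophen-2-yl and 5-bromofuran-2-yl cannot be told apart here (a 1.7-fold lower number from compound 1 to compound 3 (0.22 log units; within the scatter)), so compound 2 alone stands apart among the three compounds. No measurement at hand accounts for these differences.

Because the step from compound 2 to compound 3 exchanges the ring and removes the acetyl group at once, the compounds shown leave open how much of it belongs to each change; an unsubstituted furan-2-yl would separate the two. They also leave open how an amine or a carboxylic acid in place of the acetyl group would read in this assay at this position.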